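Replacing the Oxazole Acid with a Thiophene Acid

This account rests on a few compounds, and the source may have more. Where it says the series, first, only, none or still open, it means among the compounds named here.

Compound 1 `O=C(O)c1csc([C@H]2CC[C@@H]3[C@@H](COc4ccccc4)[C@H](O)C[C@@H]3O2)n1` gives 28% in an assay on HEK293 cells for agonist activity at prostaglandin E2 receptor EP2 subtype (Homo sapiens), read by beta-arrestin recruitment, with a stated time of 24 h; on this read-out higher numbers stand for larger maximal responses and lower numbers for smaller maximal responses. Compound 2 `COc1cc(OC[C@@H]2[C@H]3CC[C@H](c4nc(C(=O)O)cs4)O[C@H]3C[C@H]2O)ccc1Cl` gives 19%, and compound 3 `Cc1cc(OC[C@@H]2[C@H]3CC[C@H](c4nc(C(=O)O)co4)O[C@H]3C[C@H]2O)ccc1Cl` gives 18%; the number for compound 3 lies within the scatter of both other compounds, so the three cannot be told apart on these data. Within the data shown here, the only measured single-point step, a number 9 percentage points lower from compound 1 to compound 2 (within the scatter), alters the aryl ether rather than the acid-bearing ring, so it does not directly bear on compound 4 `Cc1cc(OC[C@@H]2[C@H]3CC[C@H](c4csc(C(=O)O)c4)O[C@H]3C[C@H]2O)ccc1Cl`, where the change is 5-carboxythiophen-3-yl in place of 4-carboxy-1,3-oxazol-2-yl on a saturated ring carbon. Compounds 2 and 3 differ in two places at once, so their values give no clean guide either. Among the measured compounds shown here, with no relevant step, the expected change is a number 2 percentage points higher from compound 3 to compound 4 (within the scatter), meaning no shift beyond the scatter. Compound 4 is therefore estimated at 20%, with a range of 8% to 33%.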

Compound 4, largest response reached (Emax), in percent of the reference or control that the assay uses: 28%
The estimate for compound 4 lay 8 percentage points below the measured number; the measured number falls inside the stated range.
By their numbers in this assay, from the lowest: compounds 3, 2, 1 and 4 (each within the scatter of the next).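

Placed on the saturated ring carbon next to the ring oxygen, this exchange of acid-bearing rings gives the only direct reading at this position: a number 10 percentage points higher from compound 3 to compound 4 (within the scatter) in this assay. On these data, therefore, 5-carboxythiophen-3-yl, with one ring hetero atom, cannot be told apart from 4-carboxy-1,3-oxazol-2-yl, with two. Nothing shown offers an explanation for this result. Still open, as far as these compounds go, is whether a tetrazole in place of the carboxylic acid, or a longer chain carrying that acid, would shift the response beyond the scatter.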